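Swapping chloro for trifluoromethyl on an anticonvulsant side ring

The source may hold more compounds than are shown below. What is called first, only, known or untested is meant among the compounds shown, and "the series" means these compounds.

Of the compounds shown here, three of a shared core have been tested in a functional assay on the whole organism (strain CD1) with Mus musculus as the target, in the maximal electroshock model, with a stated time of 0.5 h; on this read-out higher numbers stand for an effect only at larger amounts of compound and lower numbers for an effect already at smaller amounts. Compound 1 `CC1CC(=O)N(CC(=O)N2CCN(c3ccc(Cl)cc3)CC2)C1=O` gives 100 mg/kg in this assay. Compound 2 `CC1CC(=O)N(CC(=O)N2CCN(c3cccc(Cl)c3)CC2)C1=O`, where only the side ring differs, gives 100 mg/kg in this assay, and compound 3 `CCC1(C)CC(=O)N(CC(=O)N2CCN(c3ccccc3C)CC2)C1=O` gives 100 mg/kg in this assay. Compound 2 therefore stands level with compounds 1 and 3, all within the usual scatter of one another. Within the data shown here, the one single-point step recorded, no change at the digits printed from compound 1 to compound 2 (within the scatter), shows that moving the chloro from one position of the side ring to another left the dose unchanged.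

Compound 4 `CC1CC(=O)N(CC(=O)N2CCN(c3cccc(C(F)(F)F)c3)CC2)C1=O` has not yet been measured. It differs from compound 2 in one place: trifluoromethyl in place of chloro on an aromatic carbon. Among the measured compounds shown here, only the step from compound 1 to compound 2 bears on a change at this ring, and it shows no movement, so nothing beyond the scatter is expected in this assay; the estimated step of no change at the digits printed from compound 2 to compound 4 (within the scatter) is flat. Compound 4 is expected to give 100 mg/kg, within a range from 50 mg/kg to 300 mg/kg.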

Compound 4, minimum effective dose: 100 mg/kg
The estimate for compound 4 equals the measured number at the digits printed, and the stated range covers the measured number.
By their numbers in this assay, from the lowest: compounds 1, 2, 3 and 4 (each within the scatter of the next).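

The earlier compounds shown here only moved a chloro around the side ring, while here the group itself is exchanged at one aromatic carbon, and this assay records no change at the digits printed from compound 2 to compound 4 (within the scatter). At this position, then, trifluoromethyl with 4 heavy atoms is tolerated in place of chloro with 1 heavy atom, so this read-out does not separate the two groups in this pair. No measurement shown here offers an explanation for this flat result.

On these data alone, whether a nitrile, an amine or a carboxylic acid on the same aromatic carbon would shift the dose remains open. So does whether trifluoromethyl would behave the same way on the side ring of compound 1, or with the ethyl and methyl pair of the core of compound 3.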